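Pyridinyl position swap in a cytotoxicity series

The source may hold more compounds than are shown below. What is called first, only, known or untested is meant among the compounds shown, and "the series" means these compounds.

Measured compounds, read in a functional assay on HepG2 cells (Homo sapiens) for cytotoxicity, read by MTT assay, with a stated time of 24 h; on this read-out higher numbers stand for weaker inhibition and lower numbers for stronger inhibition:
compound 1 `CN1C/C(=C\c2cccnc2)C(=O)/C(=C/c2ccccc2F)C1` gives 4810 nM
compound 2 `O=C1/C(=C/c2cccnc2)CN(S(=O)(=O)c2ccc(C(F)(F)F)cc2)C/C1=C\c1ccccc1F` gives 2400 nM
compound 3 `N#Cc1ccc(S(=O)(=O)N2C/C(=C\c3cccnc3)C(=O)/C(=C/c3ccccc3F)C2)cc1` gives 6600 nM

Compound 3 carries the highest number of the three. Against compound 1 the step of a 1.4-fold higher number from compound 1 to compound 3 (0.14 log units; within the scatter) lies within the scatter, so the two cannot be ordered. Against compound 2 the step of a 2.8-fold higher number from compound 2 to compound 3 (0.44 log units; beyond the scatter) is modest but beyond the scatter, so compound 3 is the weaker inhibitor of that pair.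

Compound 4 `N#Cc1ccc(S(=O)(=O)N2C/C(=C\c3ccncc3)C(=O)/C(=C/c3ccccc3F)C2)cc1` keeps every atom of compound 3 and differs only in how the pyridinyl is joined: pyridin-4-yl in place of pyridin-3-yl on a double-bonded chain carbon bound to a double-bonded ring carbon.

Neither measured step touches this part of the molecule. The step from compound 1 to compound 3 concerns the group on the amine nitrogen in the ring, and the step from compound 2 to compound 3 concerns the group on the aromatic carbon of the sulfonyl aryl. Both pyridinyl groups carry the same count of heavy atoms and acceptors. Among the measured compounds shown here, with no step bearing on the change, the expectation in this assay is no change at the digits printed from compound 3 to compound 4 (within the scatter), no step beyond the scatter.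

Compound 4 is therefore estimated at 6600 nM, with a range from 3000 nM to 14500 nM.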

Compound 4, half-maximal inhibitory concentration: 4500 nM
Compound 4: the middle estimate sits 1.5-fold (0.17 log units) above what was measured; measured number inside the range.
By their numbers in this assay, from the lowest: compounds 2, 4, 1 and 3 (each within the scatter of the next, the first and the last beyond it).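

In this assay, the change of attachment at the double-bonded chain carbon bound to a double-bonded ring carbon gives a 1.5-fold lower number from compound 3 to compound 4 (0.17 log units; within the scatter), so pyridin-4-yl and pyridin-3-yl cannot be told apart at this place. Among the compounds shown here, the earlier steps covered only the group on the ring amine nitrogen and the group on the sulfonyl aryl, so this is the first reading at this position, and it comes from a single pair carrying the (4-cyanophenyl)sulfonyl group. No supporting measurement bears on this result, so it stands as an observation without an explanation.

On these data alone, compound 1 and compound 2 carry only pyridin-3-yl, so it remains open whether the same swap would also stay within the scatter with methyl on the ring nitrogen or with trifluoromethyl on the sulfonyl aryl. The compounds shown also include no pyridin-2-yl or plain phenyl at this place, so whether the presence or placement of the pyridine nitrogen matters at all in this assay remains open.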